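A few compounds are considered here, and "the series" means these few. Any claim that something is new, unique, unknown or untested is made for them only; others in the source may bear on it.

Four compounds share one core. Compound 1 `COCCCNc1nc(N)nc2ccccc12` is tested in an ADME assay on HEK293 cells (Homo sapiens) for cytotoxicity, with a stated time of 6 h; on this read-out lower numbers stand for higher toxicity in this test and higher numbers for lower toxicity in this test. In this assay compound 1 gives > 25000 nM, which is a limit of the assay and not a number. Compound 2 `CCCCNc1nc(N)nc2ccc(CCc3ccc(N(C)C)cc3)cc12` gives > 18000 nM in this assay, again a limit rather than a number. Compound 3 `CCCCNc1nc(N)nc2cccc(C)c12` in this assay gives > 25000 nM, also a limit of the assay. Among the measured compounds shown here, compound 3 therefore stands at the limit of > 25000 nM in this assay, at which 2 of the 3 values shown sit, while the one remaining value stands at the limit of > 18000 nM in this assay, at which 1 of the 3 values shown sits. For the measured compounds named here, none of the three values is a measured number, so no step between measured compounds can be stated in this assay, and the values show only that all three sit at a limit.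

Compound 4 `CCCCNc1nc(N)nc2cccc(C(=O)NC(C)C)c12` has not yet been measured. It differs from compound 3 by isopropylcarbamoyl in place of methyl on an aromatic carbon. Going by the values given here, with no measured step to lean on and all three neighbours at a limit, the expectation for this assay is a step of no size beyond the usual scatter, in no set direction, most likely ending once more at a limit rather than a number. Compound 4 is expected at 30000 nM, with a range from 10000 nM to 100000 nM. The expected step is a step that the limit leaves unreadable from compound 3 to compound 4.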

Compound 4, half-maximal cytotoxic concentration: > 25000 nM
Compound 4 gave a limit, no number; the forecaster's own chance of this, stated with the estimate: 75%; the middle value lies beyond the limit too.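

In this assay compound 4 gives > 25000 nM, a limit of the assay and not a number. Among the compounds shown here, compound 3 also stands at a limit, so no step between compound 3 and compound 4 can be read. The compounds shown leave open at what concentration, if any within reach of this assay, isopropylcarbamoyl in place of methyl would make a difference.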